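The compounds below may be only part of what the source reports. "The series", "measured", "known", "first", "only" and "open" are said of these compounds alone.

The study follows a small set of analogues built on a shared core. Compound 1 `COc1ccc(-c2cc(-c3ccc(S(=O)(=O)N(C)C)cc3)cnc2N)cn1` is examined in an in vitro ADME assay on microsomes from liver (Homo sapiens) for metabolic stability (a higher number here means that the compound lasts longer, a lower number that the compound disappears faster), where compound 1 gives 0.292 h. Of the two plain numbers obtained in this assay, that is the lower one; the nearest is compound 3 `COc1ccc(-c2cnc(N)c(-c3ccc(OC)nc3)c2)cn1`, which in this assay gives 1.45 h, a gap that lies beyond the usual scatter. Compound 2 `COc1ccc(-c2cc(-c3ccc(S(C)(=O)=O)c(F)c3)cnc2N)cn1` in this assay reaches only a limit of the assay, > 4.16 h, and not a number (the limit of > 4.16 h in this assay, at which 1 of the 3 values shown sits). The compound still to be measured is compound 4 `COc1ccc(-c2cc(-c3ccc(C(N)=O)cc3)cnc2N)cn1`. It differs from compound 1 in a single place: carbamoyl in place of dimethylsulfamoyl on an aromatic carbon. Going by the values given here, no measured pair differing in just that way is available, so any expectation rests on the reading of compound 1 at 0.292 h. The step is expected to be a moderate rise, around a 2.7-fold higher number from compound 1 to compound 4 (0.44 log units; beyond the scatter), somewhat beyond the scatter but uncertain in size. In this assay compound 4 is estimated at 0.8 h, with a plausible range from 0.3 h to 2.5 h.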

Compound 4, half-life in the Homo sapiens assay: > 4.16 h
Compound 4 ended at the assay's limit; the forecaster's own chance of this, stated with the estimate: 10%; middle value at least 5.2-fold (0.71 log units) away from the limit.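

Going by these compounds alone, in the Homo sapiens assay the exchange of dimethylsulfamoyl for carbamoyl gives an at least 14-fold higher number from compound 1 to compound 4 (1.15 log units; beyond the scatter), the first single-place step in this set, and it shows that the group at this position strongly affects the read-out. In the Homo sapiens assay compound 4 gives a limit of the assay and not a number, > 4.16 h. In a physicochemical assay for lipophilicity, at pH 7.4 (a lower number here means a more polar compound, a higher number a more lipophilic compound), compound 1 gives 2.8 and compound 4 gives 1.7. The rise comes with a more polar compound, which may contribute to it, although one pair cannot separate polarity from the change of group itself: the measured distribution coefficient of compound 1, 2.8, and of compound 4, 1.7, a number 1.10 log units lower (beyond the scatter)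

On these data alone, how much longer compound 4 lasts beyond its limit stays open, and so does the full size of the step. As far as these compounds go, it is also open whether the rise is particular to carbamoyl or would also appear with a nitrile or a carboxylic acid on the same aromatic carbon.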